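The source may report more compounds than this note shows. Statements on the series, on what has been measured and on what is new or still open speak of the compounds shown alone.

Compound 1 `CCc1ccccc1NS(=O)(=O)c1ccc(N2CCNC2=O)cc1`: 180 nM
Compound 2 `CCc1cccc(NS(=O)(=O)c2ccc(N3CCNC3=O)cc2)c1`: 82 nM

In a functional assay on M21 cells (Homo sapiens) for antiproliferative activity, read by sulforhodamine B assay, with a stated time of 48 h (on this read-out lower numbers stand for stronger inhibition and higher numbers for weaker inhibition), compound 2 gives 82 nM, the lower of the two numbers and so the stronger inhibition of the pair. Compound 3 `O=C1NCCN1c1ccc(S(=O)(=O)Nc2ccc(Br)cc2)cc1` keeps the shared core but carries 4-bromophenyl in place of 3-ethylphenyl on a sulfonamide nitrogen. Among the measured compounds shown here, only one measured step bears on this change: a 2.2-fold lower number from compound 1 to compound 2 (0.34 log units; beyond the scatter), with 3-ethylphenyl in place of 2-ethylphenyl on that same nitrogen. That step was modest, though beyond the scatter. For the measured compounds named here, no measured compound carries a 4-bromophenyl group, so the direction is uncertain, and a step of about that modest size is the most these data support. A small move towards a higher number is expected, and the estimated change is a 1.6-fold higher number from compound 2 to compound 3 (0.20 log units; within the scatter). The estimated value for compound 3 is 130 nM, with an expected range from 40 nM to 400 nM.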

Compound 3, half-maximal inhibitory concentration: 130 nM
Compound 3: middle estimate and measured number agree at the digits printed; the range from low to high includes it.
By their numbers in this assay, from the lowest: compounds 2, 3 and 1 (each within the scatter of the next, the first and the last beyond it).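

Putting a bromine-bearing ring on the sulfonamide nitrogen shows that this position tolerates more than ethyl-substituted rings: in this assay, 4-bromophenyl in place of 3-ethylphenyl gives a 1.6-fold higher number from compound 2 to compound 3 (0.20 log units; within the scatter) and so cannot be told apart from compound 2. Set against 2-ethylphenyl, the same group gives a 1.4-fold lower number from compound 1 to compound 3 (0.14 log units; within the scatter) and so cannot be told apart from compound 1 either, even though compounds 1 and 2 differ from each other beyond the scatter. No evidence is available to explain why the numbers fall this way.

Going by these compounds, whether an amine, a carboxylic acid or a longer chain on this ring would keep the number in the same range remains open. So does the separate contribution of the bromine and of its place on the ring, which a 4-ethylphenyl or 3-bromophenyl group could address.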